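One Methyl Group, Two Placements, One Open Question

This account rests on a few compounds, and the source may have more. Where it says the series, first, only, none or still open, it means among the compounds named here.

Measured so far:
- compound 1, `COc1cc(/C=C/C(=O)c2sc(Nc3ccccc3)nc2C)cc(OC)c1OC`: > 25000 nM
- compound 2, `COc1cc(/C=C/C(=O)c2sc(Nc3ccccc3C)nc2C)cc(OC)c1OC`: 6320 nM
- compound 3, `Cc1nc(Nc2ccccc2)sc1C(=O)/C=C/c1ccccc1Cl`: > 25000 nM

All three compounds were tested in a functional assay on NCI-H460 cells (Homo sapiens) for cytotoxicity, read by MTT assay; on this read-out lower numbers stand for stronger inhibition and higher numbers for weaker inhibition. For compound 1 the result is only a limit of the assay, > 25000 nM. Compound 2 carries the change methyl in place of hydrogen on an aromatic carbon and gives 6320 nM. That step, an at least 3.9-fold lower number from compound 1 to compound 2 (0.59 log units; beyond the scatter), is beyond the usual scatter, though its true size is open because compound 1 sits at the limit of > 25000 nM in this assay, at which 2 of the 3 values shown sit.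

Compound 3 likewise returns only a limit, > 25000 nM. How the core of compound 3 differs from the core of compound 1 is not broken down here.

Compound 4, `Cc1ccc(Nc2nc(C)c(C(=O)/C=C/c3ccccc3Cl)s2)cc1`, is not yet measured. It differs from compound 3 by methyl in place of hydrogen on an aromatic carbon. For the measured compounds named here, this is the same kind of change as the one from compound 1 to compound 2, but not the same: in compound 2 the methyl sits ortho to a large group, in compound 4 it sits para to a large group.

The starting point, compound 3, gives only a limit of the assay, > 25000 nM. Going by the values given here, the only precedent is the step of an at least 3.9-fold lower number from compound 1 to compound 2 (0.59 log units; beyond the scatter), which comes from a single pair with a different placement. On that basis the expectation for compound 4 is a step of an at least 1.2-fold lower number from compound 3 to compound 4 (0.09 log units; that floor lies within the scatter), and compound 4 is estimated at 20000 nM, with a fair chance that this assay again reports only a limit.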

Compound 4, half-maximal inhibitory concentration: > 25000 nM
Compound 4: a limit, no number; the forecaster's own chance of this, stated with the estimate: 55%; middle value at least 1.2-fold (0.09 log units) away from the limit.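

Compound 3 and compound 4 both return only a limit in this assay, not a number, so no step between them can be read: the limit of > 25000 nM in this assay, at which 3 of the 4 values shown sit.

The compounds shown leave open whether a methyl para to a large group, as in compound 4, changes the read-out at all, and whether the placement of the methyl matters when compound 4 is set against compound 2.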